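A few compounds are considered here, and "the series" means these few. Any claim that something is new, unique, unknown or untested is made for them only; others in the source may bear on it.

Measured so far in an assay on isolated protein for displacement of a labelled ligand from metabotropic glutamate receptor 5 (Homo sapiens), with a stated time of 60 min, tested at 1 uM; on this read-out higher numbers stand for more inhibition at the one concentration tested (going by the name of the read-out) and lower numbers for less inhibition:

compound 1 `COc1ccc(S(=O)(=O)c2cnc3c(F)cccc3c2N2CCC(C)CC2)cc1` gives 67%
compound 2 `CC1CCN(c2c(S(=O)(=O)c3ccc(Cl)c(Cl)c3)cnc3c(F)cccc23)CC1` gives 95%
compound 3 `CC1CCN(c2c(S(=O)(=O)c3ccc(Cl)c(Cl)c3)cnc3cc(Cl)ccc23)CC1` gives 89%

Compound 2 and compound 1 differ by one change, (4-methoxyphenyl in place of 3,4-dichlorophenyl on a sulfonyl sulfur), and this made a step of a number 28 percentage points lower from compound 2 to compound 1 (beyond the scatter), a modest loss. Compound 3 shares the sulfonyl-linked 3,4-dichlorophenyl with compound 2 but has a different core; the difference between the two cores is not broken down here, and their two values lie within the usual scatter of each other. Compound 3 sits beyond the scatter from compound 1.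

Compound 4 `COc1ccc(S(=O)(=O)c2cnc3cc(Cl)ccc3c2N2CCC(C)CC2)cc1` is compound 3 with the same change, (4-methoxyphenyl in place of 3,4-dichlorophenyl on a sulfonyl sulfur). Going by the values given here, only one earlier instance of this change exists, so the expectation rests on it alone: the step from compound 3 to compound 4 is estimated at a number 28 percentage points lower from compound 3 to compound 4 (beyond the scatter), close to the earlier a number 28 percentage points lower from compound 2 to compound 1 (beyond the scatter). On that basis compound 4 is expected to give about 61% in this assay, likely between 45% and 76%.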

Compound 4, a percentage reported as inhibition, at one concentration (the size of the read-out at that concentration, not a potency): 79%
Compound 4: middle estimate off by 18 percentage points, on the low side; the whole stated range lies below it.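

The change from 3,4-dichlorophenyl to 4-methoxyphenyl on a sulfonyl sulfur gives a number 10 percentage points lower from compound 3 to compound 4 (within the scatter), so on the core of compound 3 it leaves no loss that stands clear of the scatter in this assay. The size of the step does not carry over directly between these two cores: the same change on two cores in this assay, a number 28 percentage points lower (beyond the scatter) from compound 2 to compound 1 and a number 10 percentage points lower (within the scatter) from compound 3 to compound 4, 18 percentage points apart, beyond the scatter of two such steps What sets the two steps apart remains unshown, since the two cores are compared through a single pair each, and two pairs establish no rule for further cores.

Open, on these data alone, is how an amine or a carboxylic acid in place of 3,4-dichlorophenyl on a sulfonyl sulfur would behave on each core. Also open, as far as these compounds go, is whether any third core would follow either step.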